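Chloro in place of benzyloxy: an expected outcome

The source may report more compounds than this note shows. Statements on the series, on what has been measured and on what is new or still open speak of the compounds shown alone.

Measured compounds:
compound 1, `Fc1cccc(Nc2nc3nonc3nc2Nc2ccccc2F)c1`, 190 nM
compound 2, `Oc1nc2nonc2nc1Nc1ccc(OCc2ccccc2)cc1`, 2400 nM

In an assay on mitochondria from L6 cells (Rattus norvegicus) for activation, with a stated time of 90 min (on this read-out higher numbers stand for an effect only at larger amounts of compound and lower numbers for an effect already at smaller amounts), compound 2 gives 2400 nM, the highest of the two numbers. Its nearest neighbour, compound 1, gives 190 nM, and that gap lies beyond the usual scatter. The two compounds differ in more than one place, so their values alone say nothing about any single change.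

Compound 3, `Oc1nc2nonc2nc1Nc1ccc(Cl)cc1`, differs from compound 2 by chloro in place of benzyloxy on an aromatic carbon. Among the measured compounds shown here, no measured pair shows this change, so its size is unknown. A step of modest size, in either direction, or none beyond the scatter, is what one would expect from a swap of this kind.

Compound 3 is therefore estimated to give about 2000 nM in this assay, with a range from 500 nM to 8000 nM. This estimate means an expected 1.2-fold lower number from compound 2 to compound 3 (0.08 log units; within the scatter).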

Compound 3, half-maximal effective concentration: 11700 nM
For compound 3 the middle estimate is 5.9-fold (0.77 log units) below the measured one; measured number above the stated range.
By their numbers in this assay, from the lowest: compound 1; then compound 2; then compound 3.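

Chloro in place of benzyloxy on this aromatic carbon gives, in this assay, a 4.9-fold higher number from compound 2 to compound 3 (0.69 log units; beyond the scatter) and so provides the first comparison here of compounds differing in one place. It shows that the number at this position depends on the group it carries, with the lower number going with benzyloxy, the group of 8 heavy atoms and a six-membered aromatic ring, rather than with the single chlorine atom. Nothing measured here bears on what lies behind this step.

With only these two groups compared at this carbon, the compounds shown do not separate the part played by the oxygen of benzyloxy from that of its ring. Methoxy, an amine or a carboxylic acid at the same place remains an open case, as does the size of this step on the core of compound 1.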